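A few compounds are considered here, and "the series" means these few. Any claim that something is new, unique, unknown or untested is made for them only; others in the source may bear on it.

Compound 2 `CCC(C)n1cnc2c(NCc3ccc(C(=O)Nc4ccccc4N)cc3)nc(Cl)nc21` gives 45% in a functional assay on HepG2 cells (Homo sapiens) for antiproliferative activity, read by CCK-8 assay, with a stated time of 72 h, tested at 2 uM (a higher number here means a stronger effect of the compound at the concentration tested, a lower number a weaker effect), the highest of the three numbers measured. Compound 3 `Nc1ccccc1NC(=O)c1ccc(COCNc2nc(Nc3ccccc3)c3ncn(C4CCCC4)c3n2)cc1` gives 37.5%, which lies within the scatter of compound 2. Compound 1 `COC(CCn1cnc2c(NCc3ccc(C(=O)Nc4ccccc4N)cc3)nc(Cl)nc21)OC` gives 8.52%, far lower, and the step of a number 36.5 percentage points higher from compound 1 to compound 2 (beyond the scatter) shows a large gain from that swap on the aromatic nitrogen. Compound 4 `CCCn1cnc2c(NCc3ccc(C(=O)Nc4ccccc4N)cc3)nc(Cl)nc21` differs from compound 2 by hydrogen in place of methyl on a saturated chain carbon bound to an aromatic nitrogen and a saturated chain carbon. For the measured compounds named here, no measured step makes exactly this change; only the step from compound 1 to compound 2 touches the same nitrogen, and it concerns a different, larger swap. A small drop, within the scatter, is therefore expected as a number 7 percentage points lower from compound 2 to compound 4 (within the scatter). Compound 4 is estimated at 38%, with a range from 20% to 55%.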

Compound 4, a percentage reported as inhibition, at one concentration (the size of the read-out at that concentration, not a potency): 12.4%
Estimate against measurement, compound 4: 25.6 percentage points above; the whole stated range lies above it.
By their numbers in this assay, from the lowest: compounds 1 and 4 (each within the scatter of the next); then compounds 3 and 2 (each within the scatter of the next).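

At this position, on a saturated chain carbon bound to an aromatic nitrogen, one methyl matters: in this assay, the change from sec-butyl to propyl gives a number 32.6 percentage points lower from compound 2 to compound 4 (beyond the scatter). The earlier compounds shown here showed a large step only for a bigger swap on this nitrogen. The propyl and 3,3-dimethoxypropyl chains, by contrast, sit within the scatter of each other, with a number 3.9 percentage points higher from compound 1 to compound 4 (within the scatter). Nothing measured here gives a reason for the drop. Still open, as far as these compounds go, is whether isopropyl or 3-pentyl would keep the higher number, and how an amine on the chain would fare.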